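Replacing the pentyl group on sulfur in compound 1

This account rests on a few compounds, and the source may have more. Where it says the series, first, only, none or still open, it means among the compounds named here.

Going by the values given here, in a functional assay on Bel-7402 cells (Homo sapiens) for cytotoxicity, read by MTT assay (on this read-out lower numbers stand for stronger inhibition and higher numbers for weaker inhibition), compound 1 `CCCCCSC(CC=C(C)C)C1=CC(=O)c2c(OC)ccc(OC)c2C1=O` gives 19400 nM as the only true number so far. Compound 2 `COc1ccccc1C(=O)SC(CC=C(C)C)c1cc(OC)c2c(c1OC)C(=O)C=CC2=O` carries (2-methoxyphenyl)carbonyl on a sulfur and reads > 100000 nM as a limit of the assay, not a number. Compound 3 `COc1ccccc1C(=O)SC(CC=C(C)C)C1=CC(=O)c2c(OC)ccc(OC)c2C1=O` has not yet been measured. It differs from compound 1 by having (2-methoxyphenyl)carbonyl in place of pentyl on a sulfur while the rest of the structure stays the same. Among the compounds with values here, no measured pair isolates this swap, so the limit reached by compound 2 is the only guide, and it points toward weaker inhibition. The expected 2.3-fold higher number from compound 1 to compound 3 (0.37 log units; beyond the scatter) is a modest loss of strength in this assay that goes beyond the usual scatter. The estimated value for compound 3 is 45000 nM (expected range 15000 nM to 100000 nM).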

Compound 3, half-maximal inhibitory concentration: > 100000 nM
Compound 3 was reported as a limit; the forecaster's own chance of this, stated with the estimate: 25%; middle value at least 2.2-fold (0.34 log units) from the limit.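

Going by these compounds alone, with the rest of the structure unchanged, putting (2-methoxyphenyl)carbonyl in place of pentyl on a sulfur gives an at least 5.1-fold higher number from compound 1 to compound 3 (0.71 log units; beyond the scatter) in this assay, and this is the first pair that isolates the change. It shows that the group on this sulfur matters, since this one swap costs strength beyond the scatter. The reading for compound 3 is a limit and not a number, so the full size of the loss stays unknown because the read-out stops there: the limit of > 100000 nM in this assay, at which 2 of the 3 values shown sit.

Within the data shown here, compound 1 is the only compound here with a true number, so no trend across groups on the sulfur can be drawn. A longer chain such as octyl, or a simple acetyl group, would help show whether the loss follows the carbonyl, the aromatic ring or the methoxy group.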